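Trimming Methoxymethoxy to Methoxy on a Hepatoma Cytotoxicity Series

The source may hold more compounds than are shown below. What is called first, only, known or untested is meant among the compounds shown, and "the series" means these compounds.

Compound 1 `COCOc1cc(O)c2c(=O)cc(C3(O)C=CC(=O)C=C3)oc2c1`: 2390 nM
Compound 2 `COC1(c2cc(=O)c3ccccc3o2)C=CC(=O)C=C1`: 5410 nM
Compound 3 `COC1(c2cc(=O)c3c(O)cccc3o2)C=CC(=O)C=C1`: 2320 nM

Of the compounds shown here, three sharing one core have been measured in a functional assay on Hep 3B2 cells (Homo sapiens) for cytotoxicity, read by colorimetric assay and MTT assay, with a stated time of 72 h; on this read-out higher numbers stand for weaker inhibition and lower numbers for stronger inhibition. Among the compounds with values here, compound 2 gives 5410 nM; a hydroxy added on the core gives compound 3, and that single step, a 2.3-fold lower number from compound 2 to compound 3 (0.37 log units; beyond the scatter), is the only one-place change among the measured compounds. Compound 1 stands second highest of the three numbers: its value lies within the scatter of compound 3 and beyond the scatter of compound 2, which has the higher number.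

The next compound is compound 4 `COc1cc(O)c2c(=O)cc(C3(O)C=CC(=O)C=C3)oc2c1`, not yet measured. It differs from compound 1 in one place: hydrogen in place of methoxy on a saturated chain carbon bound to an oxygen on an aromatic ring. Within the data shown here, none of the measured steps bears on this change. Among the measured compounds shown here, the only measured step concerns a hydroxy in place of hydrogen on an aromatic carbon, not the methoxymethoxy group, so there is nothing in these numbers to say which way the methoxymethoxy to methoxy change should go. For the measured compounds named here, with no comparable step, the expectation is a number near that of compound 1, with a step no larger than the scatter in either direction.

On that basis compound 4 is expected to give about 2400 nM, within a range from 1100 nM to 5200 nM. The step this estimate implies is a 1.0-fold higher number from compound 1 to compound 4 (0.00 log units; within the scatter).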

Compound 4, half-maximal inhibitory concentration: 670 nM
For compound 4 the middle estimate is 3.6-fold (0.55 log units) above the measured one; measured number below the stated range.
By their numbers in this assay, from the lowest: compound 4; then compounds 3 and 1 (each within the scatter of the next); then compound 2.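

In this assay, within the data shown here, trimming methoxymethoxy to methoxy on the shared core gives a 3.6-fold lower number from compound 1 to compound 4 (0.55 log units; beyond the scatter), and this is the first sign that the group at this place bears on the read-out. The earlier step, hydroxy in place of hydrogen on an aromatic carbon, concerned another change and gave no indication of how this group would behave, whereas the shorter group here goes with stronger inhibition by more than the usual scatter. Nothing available accounts for this shift, and the step shows only its direction and size, not its origin.

The compounds shown compare only two groups at this place, so they leave open whether the number would keep falling with a free hydroxy or would rise again with an ethoxy group, a longer alkoxy chain or a chain ending in an amine. They also leave open whether the same trimming would give a similar step on a core carrying other changes, such as the methoxy that compound 3 has in place of the hydroxy on the non-aromatic ring of compound 1.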